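A few compounds are considered here, and "the series" means these few. Any claim that something is new, unique, unknown or untested is made for them only; others in the source may bear on it.

Measured so far:
- compound 1, `CCn1c(=O)c2nc(-c3ccc(S(=O)(=O)NCC(C)O)cc3)[nH]c2n(CC)c1=O`, 4.2 nM
- compound 2, `Cn1c(=O)c2nc(-c3ccc(I)cc3)[nH]c2n(C)c1=O`, 1.3 nM

In an assay for binding affinity to adenosine receptor A1 (Bos taurus) (a higher number here means a weaker inhibitor, a lower number a stronger inhibitor), compound 1 gives 4.2 nM. In this assay, going by the values given here, compound 2 gives 1.3 nM, the lowest of the two numbers; its only neighbour is compound 1, which sits higher by a step that lies beyond the usual scatter. Compound 2 is therefore the stronger of the two binders on the numbers shown.

The step to compound 3, `CCOc1ccc(-c2nc3c(=O)n(C)c(=O)n(C)c3[nH]2)cc1`, keeps the core of compound 2 and changes one group on the aromatic ring: ethoxy in place of iodo on an aromatic carbon. Among the compounds with values here, no measured pair in this set reports the same exchange, so its size cannot be read from the data at hand. On the evidence of compound 2 at 1.3 nM and of compound 1 at 4.2 nM, the core tolerates different groups at this place with strong binding.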

Compound 3, half-maximal inhibitory concentration: 2 nM
For compound 3 the middle estimate is 3.0-fold (0.48 log units) above the measured one; the range from low to high includes it.
By their numbers in this assay, from the lowest: compounds 2 and 3 (each within the scatter of the next); then compound 1.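

In this assay, putting ethoxy in place of iodo on an aromatic carbon, para to a large group, gives a 1.5-fold higher number from compound 2 to compound 3 (0.19 log units; within the scatter), so this one-place exchange leaves the two compounds level within the scatter. The position therefore accepts iodo, with 1 heavy atom and no hydrogen-bond acceptor, and ethoxy, with 3 heavy atoms and 1 hydrogen-bond acceptor, with no reading of a difference on the shared core. Nothing at hand offers an explanation for this result.

Open, as far as these compounds go, is whether the same holds for other groups at this place, such as an amine, a carboxylic acid or a longer chain. Also open, from the compounds shown here alone, is how the number of compound 1 divides between its sulfonamide group and its ethyl groups on the core, as compound 1 differs from compound 2 in more than one place.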